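The compounds below may be only part of what the source reports. "The series", "measured", "known", "first", "only" and "open" are said of these compounds alone.

Measured so far in a functional assay on MDA-MB-231 cells (Homo sapiens) for inhibition, read by sulforhodamine B assay, with a stated time of 48 h (on this read-out lower numbers stand for stronger inhibition of growth and higher numbers for weaker inhibition of growth), as follows:
- compound 1 `O=C(Cc1csc2nc(-c3ccc(Br)cc3)cn12)N/N=C/c1ccccc1O` gives 3240 nM
- compound 2 `COc1cccc(OC)c1/C=N/NC(=O)Cc1csc2nc(-c3ccc(Br)cc3)cn12` gives 16200 nM

Among the measured compounds shown here, compound 2 at 16200 nM holds the higher of the two numbers in this assay so far. Compound 3 `O=C(Cc1csc2nc(-c3ccc(Br)cc3)cn12)N/N=C/c1ccc(Cl)cc1Cl` has 2,4-dichlorophenyl in place of 2,6-dimethoxyphenyl on a carbon with a double bond to nitrogen and is not yet measured. For the measured compounds named here, one measured step bears on this place, the modest 5.0-fold higher number from compound 1 to compound 2 (0.70 log units; beyond the scatter) on leaving 2-hydroxyphenyl, and no measured compound carries 2,4-dichlorophenyl. A modest move back is therefore expected, with a 2.5-fold lower number from compound 2 to compound 3 (0.40 log units; beyond the scatter) as the estimated step. Compound 3 is expected at 6500 nM with an estimated range of 2200 nM to 16000 nM in this series.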

Compound 3, concentration for 50% growth inhibition: 26300 nM
Compound 3: middle estimate off by 4.0-fold (0.61 log units), on the low side, outside the stated range (above it).
By their numbers in this assay, from the lowest: compound 1; then compounds 2 and 3 (each within the scatter of the next).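

In this assay, 2,4-dichlorophenyl and 2,6-dimethoxyphenyl on a carbon with a double bond to nitrogen cannot be told apart (a 1.6-fold higher number from compound 2 to compound 3 (0.21 log units; within the scatter)). Two different replacements of 2-hydroxyphenyl now both stand beyond the scatter from compound 1, the larger gap being (an 8.1-fold higher number from compound 1 to compound 3 (0.91 log units; beyond the scatter)), so compound 1 alone holds the lower number among these three. Nothing measured here accounts for this. Going by these compounds, whether an aminophenyl or a carboxyphenyl group at this place would match 2-hydroxyphenyl remains open. So does whether compound 1 can be improved upon through any other group there.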